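A few compounds are considered here, and "the series" means these few. Any claim that something is new, unique, unknown or untested is made for them only; others in the source may bear on it.

Compound 1, `CC(C)(C)c1ccc(C(=O)N2CCC3(CC2)C(=O)N(CC(=O)NCCN)CN3c2ccccc2)cc1`, carries a (2-aminoethyl)amino group at the end of the chain on its core. In an assay on HEK293 cells for displacement of a labelled ligand from NPC1-like intracellular cholesterol transporter 1 (Homo sapiens) (a lower number here means a stronger inhibitor, a higher number a weaker inhibitor), compound 1 gives 7000 nM, the second highest of the three numbers at hand. Compound 2, `CC(C)(C)OC(=O)NCCCCCNC(=O)CN1CN(c2ccccc2)C2(CCN(C(=O)c3ccc(C(C)(C)C)cc3)CC2)C1=O`, gives 13700 nM; the step of a 2.0-fold higher number from compound 1 to compound 2 (0.29 log units; within the scatter) lies within the scatter, so capping the amino group with a large substituent left nothing that can be read. For the measured compounds named here, compound 3, `CC1(C)CC(OC(=O)CN2CN(c3ccccc3)C3(CCN(C(=O)c4ccc(C5CCCCC5)cc4)CC3)C2=O)CC(C)(C)N1`, gives 600 nM, the lowest of the three, but compound 3 differs from compound 1 in more than one place, so its number shows only that far lower values are reachable.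

Compound 4, `CCC1CCCN(C(=O)CN2CN(c3ccccc3)C3(CCN(C(=O)c4ccc(C(C)(C)C)cc4)CC3)C2=O)C1`, differs from compound 1 in one place: 3-ethylpiperidin-1-yl in place of (2-aminoethyl)amino on a carbonyl carbon. Going by the values given here, only the step from compound 1 to compound 2 bears on this change, and it stayed within the scatter; the donors lost and the ring gained in compound 4 have no measured counterpart of their own. Compound 3 is the lone hint that a ring-bearing, donor-free chain end can go with a lower number. A step of a 2.0-fold lower number from compound 1 to compound 4 (0.30 log units; within the scatter) is therefore expected, leaning toward a lower number without certainty of passing the scatter. For compound 4 the estimate is 3500 nM, within a range from 1000 nM to 12000 nM.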

Compound 4, half-maximal inhibitory concentration: 3900 nM
Beside the measured number, compound 4's estimate is 1.1-fold (0.05 log units) below it, within the range that was stated.
By their numbers in this assay, from the lowest: compound 3; then compounds 4, 1 and 2 (each within the scatter of the next, the first and the last beyond it).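

In this assay, the step (a 1.8-fold lower number from compound 1 to compound 4 (0.25 log units; within the scatter)) shows that the position on a carbonyl carbon whose other neighbour is a saturated chain carbon accepts a ring as well as an open chain, with no readable shift in the number. The earlier step between compound 1 and compound 2 had only kept a chain at this place, whereas here the (2-aminoethyl)amino group and its hydrogen-bond donors leave and the 3-ethylpiperidin-1-yl group, a six-membered non-aromatic ring without hydrogen-bond donors, enters, so for this pair neither those donors nor an open chain are needed to keep the number within the scatter. No measurement at hand explains why the exchange leaves the number within the scatter.

The compounds shown leave open whether the ethyl group on the ring matters, which a plain piperidin-1-yl group at the same carbonyl carbon would test. They also leave open whether a morpholin-4-yl group, or a chain ending in a carboxylic acid, would take this place with a number beyond the scatter of compound 1.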